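The compounds below may be only part of what the source reports. "The series", "measured", "known", "first", "only" and "open" are said of these compounds alone.

Of the compounds shown here, three sharing one core have been measured in an assay on CHO cells for displacement of a labelled ligand from adenosine receptor A3 (Homo sapiens), read by scintillation counting, tested at 10 uM; a higher number here means more inhibition at the concentration tested (going by the name of the read-out), a lower number less inhibition. Compound 1 `Cc1sc(N)c(C(=O)c2ccc(Cl)cc2)c1-c1ccccc1` gives 1% in this assay, compound 2 `CC(C)(C)Cc1csc(N)c1C(=O)c1cccc(Cl)c1` gives 8%, and compound 3 `CC(C)(C)Cc1c(-c2ccccn2)sc(N)c1C(=O)c1ccc(Cl)cc1` gives 1%. Compound 3 thus reads the same as compound 1 at the digits shown, and its gap to compound 2 stays within the usual scatter, so none of the three shows inhibition that can be told apart from the others. Compound 4 `Cc1ccccc1-c1sc(N)c(C(=O)c2ccc(Cl)cc2)c1CC(C)(C)C` differs from compound 3 in one place: 2-methylphenyl in place of pyridin-2-yl on an aromatic carbon. Among the measured compounds shown here, no step between measured compounds shows what such a swap does, so the expectation rests only on the uniformly low readings of compounds 1, 2 and 3. The step of a number 2 percentage points higher from compound 3 to compound 4 (within the scatter) is expected to stay within the scatter, in no clear direction. Compound 4 is therefore estimated at 3%, with a range from 0% to 14%.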

Compound 4, a percentage reported as inhibition, at one concentration (the size of the read-out at that concentration, not a potency): 1%
The estimate for compound 4 lay 2 percentage points above the measured number, within the range that was stated.
By their numbers in this assay, from the lowest: compounds 1, 3, 4 and 2 (each within the scatter of the next).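

Among the compounds shown here, replacing pyridin-2-yl with 2-methylphenyl on the aromatic carbon next to the ring sulfur gives the first direct step at this position: in this assay, the reading shows no change at the digits printed from compound 3 to compound 4 (within the scatter). Trading that ring nitrogen for carbon and adding a methyl group therefore leaves the two readings level, although both are too low to show much about this position. Nothing available explains this result. Going by these compounds, whether any group here can lift the reading clear of the scatter stays open. A carboxylic acid, an amine or a longer chain on this carbon would be a further test.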